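The compounds below may be only part of what the source reports. "The series", "measured", "known", "first", "only" and "open" are said of these compounds alone.

Of the compounds shown here, three have so far been measured in an ADME assay for permeability, using PAMPA (a lower number here means that the compound crosses the layer more slowly, a higher number that the compound crosses the layer faster), and their numbers sit close together. Compound 1 (`NC(=O)c1cc(-c2ccccc2)cc2c(C3CCN(S(=O)(=O)CCCN4CCCCCC4)CC3)c[nH]c12`) gives 290 nm/s there, compound 2 (`CC1(C)C[C@H](c2c[nH]c3c(C(N)=O)cc(-c4ccc(F)cc4)cc23)CCS1(=O)=O`) gives 283 nm/s and compound 3 (`NC(=O)c1cc(-c2ccccc2)cc2c(C3CCS(=O)(=O)CC3)c[nH]c12`) gives 277 nm/s on the same scale. Compound 1 therefore stands level with the other two, all three lying within the scatter of one another. Going by the values given here, no two of them differ in one place only, so no measured step is available as a guide. Compound 4 (`CCS(=O)(=O)N1CCC(c2c[nH]c3c(C(N)=O)cc(-c4ccccc4)cc23)CC1`) differs from compound 1 by one change (hydrogen in place of (azepan-1-yl)methyl on a saturated chain carbon, two bonds along the chain from a sulfonyl sulfur), which, cut one bond further out, reads 3-(azepan-1-yl)propyl to ethyl. In this assay no step beyond the scatter is expected in either direction, since compound 3 at 277 nm/s and compound 2 at 283 nm/s carry no 3-(azepan-1-yl)propyl group and still stay within the scatter of compound 1 at 290 nm/s in this measurement. The estimate amounts to a 1.0-fold lower number from compound 1 to compound 4 (0.02 log units; within the scatter) as the expected step. Compound 4 is expected at 280 nm/s with an estimated range from 170 nm/s to 430 nm/s in this measurement.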

Compound 4, apparent permeability: 250 nm/s
The estimate for compound 4 lay 1.1-fold (0.05 log units) above the measured number; the measured number falls inside the stated range.
By their numbers in this assay, from the lowest: compounds 4, 3, 2 and 1 (each within the scatter of the next).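

Going by these compounds alone, replacing (azepan-1-yl)methyl with hydrogen on a saturated chain carbon, two bonds along the chain from a sulfonyl sulfur, gives the first step in this assay between compounds that differ in one place: a 1.2-fold lower number from compound 1 to compound 4 (0.06 log units; within the scatter). At this position, therefore, the 3-(azepan-1-yl)propyl and ethyl groups stand level in this measurement, even though the change takes away 8 heavy atoms, including a seven-membered non-aromatic ring. Nothing available bears on the reason for this result.

Going by these compounds, this is a single step at this position, so it remains open whether a carboxylic acid, a primary amine or a longer chain carrying a piperidine would also stay level there. On these data alone, it also remains open whether the same change would read alike on a different core.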